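This account rests on a few compounds, and the source may have more. Where it says the series, first, only, none or still open, it means among the compounds named here.

Compound 1, with the structure `Cc1nn([C@H](C)c2ccc(Cl)cc2Cl)c2nc(N3CC[C@H](N4CCC[C@H]4C(N)=O)[C@H](C)C3)cnc12`, is the starting point of this comparison, yet it has no number to stand on: in an assay on CCRF-CEM cells for antagonist activity at C-C chemokine receptor type 4 (Homo sapiens), read by CellTiter-Glo, with stated times of 30 min and 60 min, in the presence of a further agent that is not named here (a higher number here means a weaker inhibitor, a lower number a stronger inhibitor), compound 1 is recorded only as "not determined" (no result reported). For the measured compounds named here, the one measured reference is compound 2, `Cc1nn([C@H](C)c2ccc(Cl)cc2Cl)c2nc(N3CC[C@H](N4CCC4)[C@H](C)C3)cnc12`, which carries a four-membered saturated ring with one nitrogen where compound 1 has the larger carbamoyl-bearing ring; in this assay compound 2 gives 218 nM. Compound 3, `Cc1nn([C@H](C)c2ccc(Cl)cc2Cl)c2nc(N3CC[C@H](N4CCC[C@H]4CO)[C@H](C)C3)cnc12`, is the unmeasured compound that this step leads to. The change is hydroxymethyl in place of carbamoyl on a saturated ring carbon. Going by the values given here, without a value for compound 1, no step can be sized, so nothing can be said about its direction beyond the scatter. Resting on compound 2, compound 3 is expected to give 150 nM in this assay, with an estimated range from 40 nM to 600 nM.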

Compound 3, half-maximal inhibitory concentration: 151 nM
Beside the measured number, compound 3's estimate is 1.0-fold (0.00 log units) below it; low and high end bracket the measured number.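

Compound 3 puts a number on a substituted five-membered ring at this position: 2-(hydroxymethyl)pyrrolidin-1-yl in place of azetidin-1-yl gives a 1.4-fold lower number from compound 2 to compound 3 (0.16 log units; within the scatter) in this assay. The two compounds therefore cannot be told apart in this test, so a hydroxymethyl-bearing ring is accepted here as well as the smaller azetidine. The step from compound 1 to compound 3 cannot be read, as compound 1 has no number, so the swap of carbamoyl for hydroxymethyl remains unsized (nothing available accounts for this result).

Still open, on these data alone, is how much the hydroxymethyl group itself contributes, compared with an unsubstituted pyrrolidine ring. Also open, as far as these compounds go, is whether a carboxylic acid, a primary amine or a longer hydroxyethyl chain on the same ring carbon would shift the number beyond the scatter.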